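A few compounds are considered here, and "the series" means these few. Any claim that something is new, unique, unknown or untested is made for them only; others in the source may bear on it.

Measured compounds:
compound 1 `COC(=O)C1=C(C)N(C)C(=O)NC1c1ccco1`: 31%
compound 2 `COC(=O)C1=C(C)N(C)C(=O)NC1c1ccoc1`: 7%
compound 3 `COC(=O)C1=C(C)N(C)C(=O)NC1c1cccs1`: 17%

In an assay on membranes from HEK293 cells for displacement of a labelled ligand from adenosine receptor A2b (Homo sapiens), read by scintillation counting, with a stated time of 30 min, tested at 1 uM (a higher number here means more inhibition at the concentration tested (going by the name of the read-out), a lower number less inhibition), compound 3 stands second highest of the three numbers. The steps of a number 14 percentage points lower from compound 1 to compound 3 (beyond the scatter) and a number 10 percentage points higher from compound 2 to compound 3 (within the scatter) place it clearly below the first compound and level with the second. Compound 4 `CC1=C(C(=O)OC(C)(C)C)C(c2cccs2)NC(=O)N1C` differs from compound 3 by tert-butyl in place of methyl on an oxygen next to a carbonyl group. Among the compounds with values here, every measured step, including a number 24 percentage points lower from compound 1 to compound 2 (beyond the scatter), swaps the ring on the saturated ring carbon and leaves the ester untouched, so no measured step bears directly on this change. Without such guidance, the expected step is no change at the digits printed from compound 3 to compound 4 (within the scatter), small and of uncertain direction. Compound 4 is therefore estimated at 17% in this assay, with a range from 0% to 40%.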

Compound 4, a percentage reported as inhibition, at one concentration (the size of the read-out at that concentration, not a potency): 24%
Compound 4: the middle estimate sits 7 percentage points below what was measured, and the stated range covers the measured number.
By their numbers in this assay, from the lowest: compounds 2, 3, 4 and 1 (each within the scatter of the next, the first and the last beyond it).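

In this assay, within the data shown here, this is the first measured change at the ester: tert-butyl in place of methyl on an oxygen next to a carbonyl group gives a number 7 percentage points higher from compound 3 to compound 4 (within the scatter). With 4 heavy atoms in place of 1 at this position, the two compounds cannot be told apart in this assay, a result that holds only for this one pair. Nothing measured here points to a cause.

From the compounds shown here alone, whether the same swap would give a similar result with furan-2-yl on the saturated ring carbon remains open. So does the effect of an ethyl group on that oxygen, or of a carboxylic acid or an amide in place of the ester.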